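This account rests on a few compounds, and the source may have more. Where it says the series, first, only, none or still open, it means among the compounds named here.

In a functional assay on G-361 cells (Homo sapiens) for cytotoxicity, read by MTT assay, with a stated time of 3 days (a higher number here means a weaker inhibitor, a lower number a stronger inhibitor), the measured compounds are:
Compound 1 `N#Cc1c(O)nc(SCc2nc3ccccc3[nH]2)nc1-c1ccccc1`: 3.43 nM
Compound 2 `N#Cc1c(Cl)nc(SCc2nc3ccccc3[nH]2)nc1-c1ccccc1`: 12.5 nM
Compound 3 `CCNc1nc(SCc2nc3ccccc3[nH]2)nc(-c2ccccc2)c1C#N`: 4.38 nM

Compound 3 stands at the lower end of these numbers. The series shows a 1.3-fold higher number from compound 1 to compound 3 (0.11 log units; within the scatter), and also a 2.9-fold lower number from compound 2 to compound 3 (0.46 log units; beyond the scatter). Compound 4 `N#Cc1c(Nc2nccs2)nc(SCc2nc3ccccc3[nH]2)nc1-c1ccccc1` differs from it by 1,3-thiazol-2-yl in place of ethyl on a nitrogen on an aromatic ring. The measured steps only exchange hydroxy, chloro and ethylamino on an aromatic carbon, the largest being a 3.6-fold higher number from compound 1 to compound 2 (0.56 log units; beyond the scatter). None of them puts a ring on that nitrogen, so the evidence is indirect and no shift beyond the scatter is expected. The expected change is a 1.1-fold higher number from compound 3 to compound 4 (0.06 log units; within the scatter). Compound 4 is estimated at 5 nM, with an expected range of 1.5 nM to 17 nM.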

Compound 4, half-maximal inhibitory concentration: 11.9 nM
The estimate for compound 4 lay 2.4-fold (0.38 log units) below the measured number; measured number inside the range.
By their numbers in this assay, from the lowest: compounds 1 and 3 (each within the scatter of the next); then compounds 4 and 2 (each within the scatter of the next).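

In this assay, the nitrogen on the aromatic ring responds to what it carries: 1,3-thiazol-2-yl in place of ethyl gives a step beyond the scatter (a 2.7-fold higher number from compound 3 to compound 4 (0.43 log units; beyond the scatter)), which the exchanges on the aromatic carbon alone could not show. As a whole group, (1,3-thiazol-2-yl)amino stays within the scatter of chloro (a 1.1-fold lower number from compound 2 to compound 4 (0.02 log units; within the scatter)) but not of hydroxy (a 3.5-fold higher number from compound 1 to compound 4 (0.54 log units; beyond the scatter)). No available evidence explains this shift.

From the compounds shown here alone, whether the step comes from the ring itself stays open. A cyclopropyl or phenyl group on that nitrogen, or a longer chain such as butyl, would bear on this.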